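The compounds below may be only part of what the source reports. "The series", "measured", "known", "first", "only" and "open" are said of these compounds alone.

Working notes on the series. Compound 1 `Cc1nc(C(F)(F)F)ccc1C(=O)Nc1ccc(Cl)c(-c2nc3ccccc3s2)c1` and compound 2 `Cc1nc(C(F)(F)F)ccc1C(=O)Nc1ccc(Cl)c(-n2cc3ccccc3n2)c1` share one core and differ only in the bicyclic group on the aromatic carbon ortho to the chloro group. Among the measured compounds shown here, in an assay on C3H 10T1/2 cells for inhibition of Sonic hedgehog protein (Mus musculus), read by a luciferase reporter (on this read-out lower numbers stand for stronger inhibition and higher numbers for weaker inhibition), compound 1 gives 70 nM and compound 2 gives 80 nM; the one measured step, a 1.1-fold higher number from compound 1 to compound 2 (0.06 log units; within the scatter), leaves the two within the scatter of each other. Compound 3 `Cc1nc(C(F)(F)F)ccc1C(=O)Nc1ccc(Cl)c(-c2cn3ccsc3n2)c1` carries at the same carbon (a group of 8 heavy atoms (5 carbon, 2 nitrogen, 1 sulfur; 2 five-membered aromatic rings with 2 hetero atoms each) in place of a group of 9 heavy atoms (7 carbon, 2 nitrogen; one five-membered aromatic ring with 2 hetero atoms, one six-membered aromatic ring of carbon only), on an aromatic carbon). For the measured compounds named here, the single step bearing on this change was flat, so no step beyond the scatter is expected for compound 3, with a 1.5-fold higher number from compound 2 to compound 3 (0.18 log units; within the scatter) as the estimated shift. Compound 3 is thus estimated at 120 nM in this assay, within 40 nM to 400 nM.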

Compound 3, half-maximal inhibitory concentration: 200 nM
Compound 3: middle estimate off by 1.7-fold (0.22 log units), on the low side; measured number inside the range.
By their numbers in this assay, from the lowest: compounds 1 and 2 (each within the scatter of the next); then compound 3.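

In this assay this position no longer looks flat: the group with 2 five-membered aromatic rings gives a 2.5-fold higher number from compound 2 to compound 3 (0.40 log units; beyond the scatter) and a 2.9-fold higher number from compound 1 to compound 3 (0.46 log units; beyond the scatter), both modest but beyond the scatter. The position therefore does not accept every bicyclic aromatic group equally, whereas 2H-indazol-2-yl and 1,3-benzothiazol-2-yl stayed within the scatter of each other. Nothing at hand accounts for this step.

The compounds shown leave open how a single ring, such as phenyl or pyridine, would read at this carbon. Going by these compounds, an amine such as morpholine also remains open there.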